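Moving the chloro group around the benzyl ether ring

The compounds below may be only part of what the source reports. "The series", "measured", "known", "first", "only" and "open" are said of these compounds alone.

Of the compounds shown here, three sharing one core have been measured in an assay on CHO-K1 cells for displacement of a labelled ligand from prostaglandin E2 receptor EP1 subtype (Homo sapiens); on this read-out lower numbers stand for stronger inhibition and higher numbers for weaker inhibition. Compound 1 `Cc1cc(C(=O)O)nn1Cc1cc(Br)ccc1OCc1ccccc1` gives 6.46 nM. Compound 2 `Cc1cc(C(=O)O)nn1Cc1cc(Br)ccc1OCc1ccc(F)cc1F` gives 0.525 nM, and compound 3 `Cc1cc(C(=O)O)nn1Cc1cc(Br)ccc1OCc1ccc(Cl)cc1` gives 8.71 nM. Compound 3 carries the highest of the three numbers; its nearest neighbour is compound 1, while compound 2 lies furthest from it, as the step of a 17-fold higher number from compound 2 to compound 3 (1.22 log units; beyond the scatter) shows. The step of a 1.3-fold higher number from compound 1 to compound 3 (0.13 log units; within the scatter) stays within the scatter, whereas a 12-fold lower number from compound 1 to compound 2 (1.09 log units; beyond the scatter) is a large change.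

Compound 4 `Cc1cc(C(=O)O)nn1Cc1cc(Br)ccc1OCc1ccccc1Cl` has not yet been measured. It differs from compound 3 in one respect: 2-chlorophenyl in place of 4-chlorophenyl on a saturated chain carbon bound to an oxygen on an aromatic ring. The same atoms are present, joined differently. The relevant measured steps are the two that alter the group on this saturated chain carbon. From compound 1 to compound 3 the added chloro group did nothing beyond the scatter, whereas the 2,4-difluorophenyl of compound 2 brought a large gain. Going by the values given here, no measured pair isolates a single substituent placed as in 2-chlorophenyl, so the expectation rests on the direction seen with compound 2. A moderate improvement in this assay is expected, a 2.9-fold lower number from compound 3 to compound 4 (0.46 log units; beyond the scatter), though with wide uncertainty. Compound 4 is therefore estimated at 3 nM, within a range from 0.7 nM to 12 nM.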

Compound 4, half-maximal inhibitory concentration: 3.16 nM
The estimate for compound 4 lay 1.1-fold (0.02 log units) below the measured number; measured number inside the range.
By their numbers in this assay, from the lowest: compound 2; then compound 4; then compounds 1 and 3 (each within the scatter of the next).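

In this assay, the position of the chloro group on the ring matters and not merely its presence: with the same atoms, 2-chlorophenyl in place of 4-chlorophenyl gives a 2.8-fold lower number from compound 3 to compound 4 (0.44 log units; beyond the scatter). Chloro in place of hydrogen on the phenyl of compound 1 now also produces a step beyond the scatter, a 2.0-fold lower number from compound 1 to compound 4 (0.31 log units; beyond the scatter), which the 4-chlorophenyl of compound 3 did not do, so the effect of adding one chloro group at this saturated chain carbon depends on where it sits on the ring. The 2-chlorophenyl still falls short of the 2,4-difluorophenyl, at a 6.0-fold higher number from compound 2 to compound 4 (0.78 log units; beyond the scatter), so a single chloro group does not reproduce the large gain seen with compound 2, and no measurement at hand accounts for any of these differences.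

The compounds shown leave open how much of the advantage of compound 2 belongs to fluoro rather than chloro, since no single fluoro group placed as in 2-chlorophenyl appears among them. They also leave open whether a methyl or a methoxy group in that same place would give a similar step, or whether the change is particular to halogens.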